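The compounds below may be only part of what the source reports. "The series", "measured", "known", "first", "only" and "open" are said of these compounds alone.

Compounds measured so far:
compound 1, `CCOc1ccccc1-c1ccc(-c2nc3cnccc3c(NC(C)C(=O)O)c2C#N)cc1`, giving 2.1 in a physicochemical assay for lipophilicity, read by HPLC, at pH 7.5; on this read-out lower numbers stand for lower lipophilicity and higher numbers for higher lipophilicity
compound 2, `CC[C@@H](Nc1c(C#N)c(-c2ccc(Br)cc2)nc2cnccc12)C(N)=O`, giving 2.2 in this assay

Compound 1 gives the lowest of the two numbers in this assay, but its nearest neighbour, compound 2, sits only a little higher, and that gap lies within the scatter of the measurement, so the two cannot be told apart on this read-out. For the measured compounds named here, no pair of measured compounds differs in only one place, so no single step has yet been observed in this assay.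

Compound 3, `CCOc1ccccc1-c1ccc(-c2nc3cnccc3c(NC(COC)C(N)=O)c2C#N)cc1`, is the next compound to be measured. It keeps the core of compound 1 and changes only the group on the ring nitrogen: 1-carbamoyl-2-methoxyethyl in place of 1-carboxyethyl on a nitrogen on an aromatic ring. A 1-carboxyethyl group leaving and a 1-carbamoyl-2-methoxyethyl group entering is expected to move this assay upward by a step clearly beyond the scatter. On that expectation compound 3 is estimated at 3.1, with a likely range from 2.5 to 3.7, which means an expected step of a number 1.00 log units higher from compound 1 to compound 3 (beyond the scatter). Whether the measurement lands there is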

Compound 3, distribution coefficient: 2.8
The estimate for compound 3 lay 0.30 log units above the measured number, within the range that was stated.
By their numbers in this assay, from the lowest: compounds 1 and 2 (each within the scatter of the next); then compound 3.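

On a nitrogen on an aromatic ring, 1-carbamoyl-2-methoxyethyl in place of 1-carboxyethyl gives a number 0.70 log units higher from compound 1 to compound 3 (beyond the scatter) in this assay and is the first single-place step read in this series, so this position is shown to register a change of group while the shared core stays the same. The step is modest, and it exchanges a whole group: the entering one has 7 heavy atoms against 5 and 2 hydrogen-bond acceptors against 1, with 1 hydrogen-bond donor and no net charge on either side, so several differences travel together in this one step. No measurement among those shown bears on why the number moved.

The compounds shown do not separate the part played by the carbamoyl group from that of the methoxy end of the chain, since both arrive together in this one exchange. On these data alone, a 1-carbamoylethyl group on the same nitrogen would split the step into those two parts, and how an amine or a longer chain at this place would read in this assay remains open.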